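The source may report more compounds than this note shows. Statements on the series, on what has been measured and on what is new or still open speak of the compounds shown alone.

Measured compounds:
Compound 1 `Cc1nc(C)n2c(=O)n(C)ncc12`, in a functional assay for inhibition, with Homo sapiens as the target; a higher number here means a weaker inhibitor, a lower number a stronger inhibitor: > 48000 nM, which is a limit of the assay rather than a number.
Compound 2 `CCCc1nc(C)c2cnn(C)c(=O)n12`, in this assay: 20000 nM.
Compound 3 `Cc1ncn2c(O)nncc12`, in this assay: > 48000 nM, again a limit of the assay and not a number.

Compound 1 and compound 2 share one core and differ in a single place, (ethyl in place of hydrogen on a saturated chain carbon bound to an aromatic carbon). This change brought an at least 2.4-fold lower number from compound 1 to compound 2 (0.38 log units; beyond the scatter). The size of that step is known only as a lower bound because compound 1 sits at the limit of > 48000 nM in this assay, at which 2 of the 3 values shown sit.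

Compound 4 `CCCc1ncn2c(O)nncc12` has not yet been measured. It stands to compound 3 exactly as compound 2 stands to compound 1: the same change, (ethyl in place of hydrogen on a saturated chain carbon bound to an aromatic carbon), made at the same place. The difference between the core of compound 1 and the core of compound 3 is not broken down here, so the two pairs rest on cores whose relation is not characterised; in both pairs, however, the starting compound gives only a limit in this assay.

On that basis the writer expects the step to compound 4 to be of the same kind and of similar size, an at least 1.6-fold lower number from compound 3 to compound 4 (0.20 log units; that floor lies within the scatter), resting on the measured step of an at least 2.4-fold lower number from compound 1 to compound 2 (0.38 log units; beyond the scatter). Compound 4 is therefore estimated in this assay at 30000 nM, with the expected range running from 12000 nM to 100000 nM. Since compound 3 itself gives only a limit, there is a real chance that compound 4 will likewise return a limit and no number.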

Compound 4, half-maximal inhibitory concentration: > 48000 nM
Compound 4: only a limit was reported (the forecaster's own chance of this, stated with the estimate: 45%); at least 1.6-fold (0.20 log units) between middle value and limit.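

In this assay compound 4 gives > 48000 nM, a limit of the assay and not a number. Compound 3 also stands at a limit, so no step between compound 3 and compound 4 can be read, and the set now stands as follows: the limit of > 48000 nM in this assay, at which 3 of the 4 values shown sit.

The compounds shown leave open whether ethyl in place of hydrogen lowers the number on the core of compound 3 at all.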